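Moving the Methoxy Groups: What Half-Life for Compound 3?

The source may report more compounds than this note shows. Statements on the series, on what has been measured and on what is new or still open speak of the compounds shown alone.

Compound 1 `COc1cccc(C)c1-c1nc(CN2CCC(C(=O)NCCCN3C[C@H](C)C[C@H](C)C3)CC2)c(C)o1`: 0.0767 h
Compound 2 `COc1cccc(OC)c1-c1nc(CN2CCC(C(=O)NCCCN3C[C@H](C)C[C@H](C)C3)CC2)c(C)o1`: 0.2 h

In an ADME assay on microsomes from liver (Rattus norvegicus) for metabolic stability, read by LC-MS, using NADPH, at 37 degrees C (a higher number here means that the compound lasts longer, a lower number that the compound disappears faster), compound 2 holds the higher of the two measured numbers, at 0.2 h. Compound 3 `COc1ccc(-c2nc(CN3CCC(C(=O)NCCCN4C[C@H](C)C[C@H](C)C4)CC3)c(C)o2)cc1OC` has the same atoms as compound 2, joined differently, with 3,4-dimethoxyphenyl in place of 2,6-dimethoxyphenyl on an aromatic carbon. Within the data shown here, only one measured step bears on this change, and only indirectly: a 2.6-fold higher number from compound 1 to compound 2 (0.42 log units; beyond the scatter), a modest step for methoxy in place of methyl on an aromatic carbon. Neither measured compound carries 3,4-dimethoxyphenyl, so the direction in this assay is a tentative judgement. A step of modest size towards a lower number is expected. The expected step is a 2.0-fold lower number from compound 2 to compound 3 (0.30 log units; within the scatter). For compound 3, the estimated half-life is 0.1 h, with an expected range from 0.04 h to 0.25 h.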

Compound 3, half-life: > 0.5 h
Compound 3 was reported as a limit; the forecaster's own chance of this, stated with the estimate: 5%; at least 5.0-fold (0.69 log units) between middle value and limit.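

In this assay, the two methoxy groups do not act through their presence alone: with the same atoms joined differently, 3,4-dimethoxyphenyl in place of 2,6-dimethoxyphenyl gives an at least 2.5-fold higher number from compound 2 to compound 3 (0.39 log units; beyond the scatter). Set against the 2-methoxy-6-methylphenyl group, the same 3,4-dimethoxyphenyl group gives an at least 6.5-fold higher number from compound 1 to compound 3 (0.81 log units; beyond the scatter), so at this aromatic carbon of the five-membered ring, how the groups are arranged on the phenyl ring moves the half-life, and not only which groups they are. For compound 3 the read-out is a limit and not a number: the limit of > 0.5 h in this assay, at which 1 of the 3 values shown sits.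

The compounds shown leave open how long compound 3 actually lasts, and so the full size of both steps. They also leave open whether a single methoxy group, as in 3-methoxyphenyl or 4-methoxyphenyl, would give the same result, or whether both groups are needed.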